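The source may hold more compounds than are shown below. What is called first, only, known or untested is meant among the compounds shown, and "the series" means these compounds.

Measured so far:
compound 1 `Cn1cc(C(=O)Nc2ccc(-c3ccccc3)c(C(F)(F)F)c2)c(=O)c2ncccc21`, 16 10^-6 cm/s
compound 2 `Cn1cc(C(=O)Nc2ccc(-c3ccncc3)c(C(F)(F)F)c2)c(=O)c2ccccc21`, 15 10^-6 cm/s
compound 3 `Cn1cc(C(=O)Nc2ccc(-c3ccccc3)c(C(F)(F)F)c2)c(=O)c2cccnc21`, 2.2 10^-6 cm/s

In an ADME assay on LLC-PK1 cells (Sus scrofa) for permeability (a higher number here means that the compound crosses the layer faster, a lower number that the compound crosses the layer more slowly), compound 2 gives 15 10^-6 cm/s, the second highest of the three numbers. Compound 1 gives 16 10^-6 cm/s, which lies within the usual scatter of compound 2. Compound 3 gives 2.2 10^-6 cm/s, a lower number that lies beyond the scatter.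

Compound 4 `Cn1cc(C(=O)Nc2ccc(-c3ccccc3)c(C(F)(F)F)c2)c(=O)c2ccccc21` is not yet measured in this assay. It differs from compound 2 in one place: phenyl in place of pyridin-4-yl on an aromatic carbon. Among the measured compounds shown here, no measured pair shows this change alone, so its size cannot be read from the data. Compound 1, which also carries a phenyl, gives 16 10^-6 cm/s, close to compound 2. The step is therefore expected to be small, a 1.3-fold higher number from compound 2 to compound 4 (0.12 log units; within the scatter), not beyond the scatter. Compound 4 is estimated at 20 10^-6 cm/s, between 10 10^-6 cm/s and 40 10^-6 cm/s.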

Compound 4, apparent permeability in the LLC-PK1 assay: 1.2 10^-6 cm/s
Estimate against measurement, compound 4: 17-fold (1.22 log units) above; measured number outside the range, below it.
By their numbers in the LLC-PK1 assay, from the lowest: compounds 4 and 3 (each within the scatter of the next); then compounds 2 and 1 (each within the scatter of the next).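

At this aromatic carbon, ortho to a trifluoromethyl group, the LLC-PK1 assay shows a 13-fold lower number from compound 2 to compound 4 (1.10 log units; beyond the scatter) for the exchange of pyridin-4-yl for phenyl, so one ring atom at this position can move that number by a large step. In a physicochemical assay for solubility, in simulated intestinal fluid, at pH 7.4 (a higher number here means a more soluble compound, a lower number a less soluble compound), compound 2 gives 12 ug/mL and compound 4 gives 11 ug/mL and these two values lie within the scatter of each other. Nothing measured here accounts for the step.

On these data alone, it remains open whether the same exchange gives a step of this size on the cores of compound 1 and compound 3. Also open, as far as these compounds go, is what an amine or a carboxylic acid on the ring at this position would give.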